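This account rests on a few compounds, and the source may have more. Where it says the series, first, only, none or still open, it means among the compounds named here.

Measured so far:
compound 1 `CC(=O)NC1=CS(=O)(=O)O[C@@]12[C@@H](CO[Si](C)(C)C(C)(C)C)O[C@@H](n1cc(C)c(=O)n(C)c1=O)[C@@H]2O[Si](C)(C)C(C)(C)C` — > 200000 nM
compound 2 `COC(=O)NC1=CS(=O)(=O)O[C@@]12[C@@H](CO[Si](C)(C)C(C)(C)C)O[C@@H](n1cc(C)c(=O)n(C)c1=O)[C@@H]2O[Si](C)(C)C(C)(C)C` — > 200000 nM

In a functional assay on HEL cells (Homo sapiens) (on this read-out higher numbers stand for lower toxicity in this test and lower numbers for higher toxicity in this test), compound 1 gives > 200000 nM, which is a limit of the assay and not a number. Compound 2 likewise gives > 200000 nM in this assay, again a limit and not a number. Among the compounds with values here, the one measured step, a step that the two limits leave unreadable from compound 1 to compound 2, changes methoxy in place of methyl on a carbonyl carbon; because both values rest on (the limit of > 200000 nM in this assay, at which 2 of the 2 values shown sit), its size cannot be read.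

Compound 3 `COC(=O)CCNC1=CS(=O)(=O)O[C@@]12[C@@H](CO[Si](C)(C)C(C)(C)C)O[C@@H](n1cc(C)c(=O)n(C)c1=O)[C@@H]2O[Si](C)(C)C(C)(C)C` is reached from compound 1 by 2-(methoxycarbonyl)ethyl in place of acetyl on an amine nitrogen. Within the data shown here, the only measured step touches the same amine nitrogen substituent as this change, and it is unreadable, so no measured step gives a size for what to expect. Compound 1 stands at the limit; with no readable step available, compound 3 is expected to stay at that limit as well, and the expected step that the limit leaves unreadable from compound 1 to compound 3 is none beyond the scatter. For compound 3 in this assay the estimate is 300000 nM, with a range of 150000 nM to 1000000 nM, most likely reported again only as a limit.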

Compound 3, half-maximal cytotoxic concentration: 94000 nM
Beside the measured number, compound 3's estimate is 3.2-fold (0.50 log units) above it, and the stated range ends above it.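

In this assay, the amine nitrogen substituent now gives a first readable number, with compound 3 at 94000 nM, so changes at this position can bring the read-out into the measurable range. Replacing acetyl with 2-(methoxycarbonyl)ethyl gives an at least 2.1-fold lower number from compound 1 to compound 3 (0.32 log units; beyond the scatter), and replacing methoxycarbonyl with the same group gives an at least 2.1-fold lower number from compound 2 to compound 3 (0.32 log units; beyond the scatter), so higher toxicity in this test appears with the (2-(methoxycarbonyl)ethyl)amino form and with neither of the two carbonyl groups placed on the nitrogen in the other compounds. Both sizes are only minimum sizes, and the step between the two other compounds still cannot be read: the limit of > 200000 nM in this assay, at which 2 of the 3 values shown sit.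

As far as these compounds go, it remains open whether the lower number follows the methyl ester or the ethyl chain, which a carboxylic acid in place of the ester, or a plain propyl group on the amine nitrogen, would separate. Also open, from the compounds shown here alone, is whether a longer chain carrying the same ester moves the number further from the limit or back towards it.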